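This account rests on a few compounds, and the source may have more. Where it says the series, first, only, none or still open, it means among the compounds named here.

In a functional assay on A549 cells (Homo sapiens) for antiproliferative activity, read by sulforhodamine B assay, with a stated time of 3 days (a lower number here means a stronger inhibitor of growth, a higher number a weaker inhibitor of growth), three compounds have been measured so far:

- compound 1 `COc1ccc(NC(=O)c2cccc(Nc3ncc(F)c(Nc4ccc(F)cc4)n3)c2)cc1` gives 11000 nM
- compound 2 `O=C(Nc1cccc(Nc2ncc(F)c(Nc3ccc(F)cc3)n2)c1)c1cnccn1` gives 10300 nM
- compound 3 `O=C(Nc1cc(Cl)cc(Cl)c1)c1cccc(Nc2ncc(F)c(Nc3ccc(F)cc3)n2)c1` gives 17500 nM

Compound 1 cannot be told apart from the other two on these numbers. There is a 1.1-fold lower number from compound 1 to compound 2 (0.03 log units; within the scatter) and also a 1.6-fold higher number from compound 1 to compound 3 (0.20 log units; within the scatter) here, and the remaining pair shows a 1.7-fold higher number from compound 2 to compound 3 (0.23 log units; within the scatter) as well.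

The next compound is compound 4 `Cn1ccnc1NC(=O)c1cccc(Nc2ncc(F)c(Nc3ccc(F)cc3)n2)c1` and it differs from compound 1 in one place. The difference is 1-methyl-1H-imidazol-2-yl in place of 4-methoxyphenyl on an amide-type nitrogen and so 1-methyl-1H-imidazol-2-yl stands in place of 4-methoxyphenyl on an amide-type nitrogen.

The closest guide is compound 3, which carries 3,5-dichlorophenyl at that same place and shows a 1.6-fold higher number from compound 1 to compound 3 (0.20 log units; within the scatter) in this series. Compound 2 is a looser guide, with ((pyrazin-2-yl)carbonyl)amino in place of (4-methoxyphenyl)carbamoyl, and it shows a 1.1-fold lower number from compound 1 to compound 2 (0.03 log units; within the scatter) on the same scale. On these data alone, neither compound carries a five-membered aromatic ring, so the new group itself is untested. Changes in this part of the molecule have so far stayed within the scatter, and no step beyond it is expected in this assay for this change either. The expected step is a 1.0-fold lower number from compound 1 to compound 4 (0.02 log units; within the scatter) as an estimate only. For compound 4 the estimated value is 10500 nM with an expected range from 4500 nM to 21000 nM in this measure.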

Compound 4, concentration for 50% growth inhibition: 10100 nM
The estimate for compound 4 lay 1.0-fold (0.02 log units) above the measured number; the measured number falls inside the stated range.
By their numbers in this assay, from the lowest: compounds 4, 2, 1 and 3 (each within the scatter of the next).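

In this assay, replacing 4-methoxyphenyl, a six-membered aromatic ring of carbon only, with 1-methyl-1H-imidazol-2-yl, a five-membered aromatic ring with 2 hetero atoms, on the amide-type nitrogen gives a 1.1-fold lower number from compound 1 to compound 4 (0.04 log units; within the scatter), so the first five-membered ring tested at this place leaves the number where it was. The comparison with the 3,5-dichlorophenyl group at the same place gives a 1.7-fold lower number from compound 3 to compound 4 (0.24 log units; within the scatter), and the looser comparison with the pyrazine-bearing amide gives a 1.0-fold lower number from compound 2 to compound 4 (0.01 log units; within the scatter), so all three steps show that neither ring size nor the hetero atoms in the ring separate these compounds in this assay. Nothing available explains why these different rings give numbers that cannot be told apart.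

The compounds shown all carry an aromatic ring at this part of the molecule, so it remains open whether a group without one, such as a longer carbon chain, an amine or a carboxylic acid, would produce a step beyond the scatter. On these data alone, it also remains open whether changes elsewhere on the shared core would move the number more than changes at this place have.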